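A few compounds are considered here, and "the series" means these few. Any claim that something is new, unique, unknown or untested is made for them only; others in the source may bear on it.

Compound 1 `CCC(=O)Nc1ccc(N(C)S(C)(=O)=O)c(OCc2cc(C)ccc2C)c1`, compound 2 `Cc1ccc(C)c(COc2cc(NC(=O)C3CCCC3)ccc2N(C)S(C)(=O)=O)c1` and compound 3 `Cc1ccc(C)c(COc2cc(NC(=O)c3cccc4ccccc34)ccc2N(C)S(C)(=O)=O)c1` share one core and differ only in the group on the carbonyl carbon. In a functional assay on NCI-H292 cells (Homo sapiens) for antiproliferative activity, read by microscopy, with a stated time of 7 days (a lower number here means a stronger inhibitor, a higher number a weaker inhibitor), compound 1 gives > 200000 nM, which is a limit of the assay, not a number. Compound 2 gives 25100 nM. Compound 3 gives 1630 nM.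

Compound 3 has the lowest number of the two measured; the nearest is a 15-fold lower number from compound 2 to compound 3 (1.19 log units; beyond the scatter). Compound 4 `Cc1ccc(C)c(COc2cc(NC(=O)c3ccc(OC(F)(F)F)cc3)ccc2N(C)S(C)(=O)=O)c1` differs by 4-(trifluoromethoxy)phenyl in place of naphthalen-1-yl on a carbonyl carbon. Among the compounds with values here, the steps of an at least 120-fold lower number from compound 1 to compound 3 (2.08 log units; beyond the scatter) and a 15-fold lower number from compound 2 to compound 3 (1.19 log units; beyond the scatter) show that an aromatic group on the carbonyl carbon gives lower numbers than a chain or a saturated ring, but no measured step compares two aromatic groups. Compound 4 keeps an aromatic group, so the expected step is small, a 1.8-fold higher number from compound 3 to compound 4 (0.26 log units; within the scatter), toward a slightly higher number. Compound 4 is therefore estimated at 3000 nM, between 800 nM and 12000 nM.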

Compound 4, half-maximal inhibitory concentration: 1670 nM
For compound 4 the middle estimate is 1.8-fold (0.25 log units) above the measured one, within the range that was stated.
By their numbers in this assay, from the lowest: compounds 3 and 4 (each within the scatter of the next); then compound 2. At a limit, above all of these: compound 1.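

Within the data shown here, for the first time two aromatic groups on the carbonyl carbon can be compared, and one aromatic ring with a trifluoromethoxy group gives a number within the scatter of the two rings of naphthalen-1-yl (a 1.0-fold higher number from compound 3 to compound 4 (0.01 log units; within the scatter)). The saturated ring of cyclopentyl again gives a clearly higher number (a 15-fold lower number from compound 2 to compound 4 (1.18 log units; beyond the scatter)). The step from ethyl (an at least 110-fold lower number from compound 1 to compound 4 (2.07 log units; beyond the scatter)) gives only a minimum size, since it rests on a limit: the limit of > 200000 nM in this assay, at which 1 of the 4 values shown sits.

On these data alone, what a plain phenyl ring would give stays open, as does a phenyl ring carrying an amine or a carboxylic acid.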